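The source may report more compounds than this note shows. Statements on the series, on what has been measured and on what is new or still open speak of the compounds shown alone.

Compound 1 `COc1cc2c(Oc3ccc(NC(=O)c4nn(-c5ccccc5OC(F)(F)F)c(=O)cc4C)cc3F)ccnc2cc1OCCCN1CCCC1`: in a functional assay on A549 cells (Homo sapiens) for inhibition, read by MTT assay, with a stated time of 72 h (on this read-out lower numbers stand for stronger inhibition and higher numbers for weaker inhibition), compound 1 gives 140 nM.
Compound 2 `COc1cc2c(Oc3ccc(NC(=O)c4nn(-c5ccccc5OC(F)(F)F)c(=O)cc4C)cc3F)ccnc2cc1OCCCN1CCCCC1`: in this assay compound 2 gives 120 nM.
Compound 3 `COc1cc2c(Oc3ccc(NC(=O)c4nn(-c5ccccc5OC(F)(F)F)c(=O)cc4C)cc3F)ccnc2cc1OCCCN1CCC(C)CC1`: in this assay compound 3 gives 90 nM.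

Compound 3 has the lowest number of the three, but its steps to the others, a 1.6-fold lower number from compound 1 to compound 3 (0.19 log units; within the scatter) and a 1.3-fold lower number from compound 2 to compound 3 (0.12 log units; within the scatter), lie within the scatter, so the three compounds cannot be told apart. Compound 4 `COc1cc2c(Oc3ccc(NC(=O)c4nn(-c5cccc(F)c5)c(=O)cc4C)cc3F)ccnc2cc1OCCCN1CCC(C)CC1` differs from compound 3 at another place: 3-fluorophenyl in place of 2-(trifluoromethoxy)phenyl on an aromatic nitrogen. For the measured compounds named here, none of the measured steps touches this part of the molecule; they all vary the saturated amine ring at the chain end, and each stayed within the scatter. The effect of changing the aromatic group on the ring nitrogen is therefore unknown, and the estimate is wide. Compound 4 is expected to give about 150 nM in this assay, between 40 nM and 600 nM, a step of a 1.7-fold higher number from compound 3 to compound 4 (0.22 log units; within the scatter) in expectation.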

Compound 4, half-maximal inhibitory concentration: 250 nM
Estimate against measurement, compound 4: 1.7-fold (0.22 log units) below; the measured number falls inside the stated range.
By their numbers in this assay, from the lowest: compounds 3, 2, 1 and 4 (each within the scatter of the next, the first and the last beyond it).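

Changes at the amine ring stayed within the scatter, but changing the group on the aromatic nitrogen in this assay goes beyond it, with a 2.8-fold higher number from compound 3 to compound 4 (0.44 log units; beyond the scatter). This position therefore affects the read-out, and of these two groups, 2-(trifluoromethoxy)phenyl gives the stronger inhibition. No available evidence explains the difference.

The substituent and its place on the phenyl ring change together here, so their contributions cannot be separated. Plain phenyl, 2-fluorophenyl and 3-(trifluoromethoxy)phenyl on this nitrogen remain open, as does whether the step holds with other amine rings.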